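Swapping a bromobenzyl amine for a piperidinylpropyl amine

The compounds below may be only part of what the source reports. "The series", "measured", "known", "first", "only" and "open" are said of these compounds alone.

Three sulfamate esters built on one shared core have been tested in an assay on HEK293 cells for inhibition of Steryl-sulfatase (Homo sapiens), tested at 1 uM; a higher number here means a stronger effect of the compound at the concentration tested, a lower number a weaker effect. Compound 1 `NS(=O)(=O)Oc1ccc2c(c1)CN(C(=O)c1ccc(N3CCCCC3)cc1)CC2` gives 38.3%, and compound 2 `NS(=O)(=O)Oc1ccc2c(c1)CN(C(=O)c1ccc(N3CCC(N4CCCCC4)CC3)cc1)CC2` gives 53.7%, so that a number 15.4 percentage points higher from compound 1 to compound 2 (beyond the scatter). Compound 3 `CCN(Cc1cccc(Br)c1)c1cccc(C(=O)N2CCc3ccc(OS(N)(=O)=O)cc3C2)c1` gives 24.9%, the lowest of the three numbers, beyond the scatter from both others. The step to compound 4 `CN(CCCN1CCCCC1)c1cccc(C(=O)N2CCc3ccc(OS(N)(=O)=O)cc3C2)c1` is methyl(3-(piperidin-1-yl)propyl)amino in place of (3-bromobenzyl)(ethyl)amino on an aromatic carbon. Among the compounds with values here, no measured step repeats this exchange, but the only related step, a number 15.4 percentage points higher from compound 1 to compound 2 (beyond the scatter), also brought in a piperidin-1-yl group and was modest. For compound 4 a modest rise is therefore expected, a number 13.1 percentage points higher from compound 3 to compound 4 (beyond the scatter), though the change is larger and less certain. Compound 4 is estimated at 38%, with a range from 20% to 58%.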

Compound 4, a percentage reported as inhibition, at one concentration (the size of the read-out at that concentration, not a potency): 30.6%
Compound 4: the middle estimate sits 7.4 percentage points above what was measured, and the stated range covers the measured number.
By their numbers in this assay, from the lowest: compounds 3, 4 and 1 (each within the scatter of the next, the first and the last beyond it); then compound 2.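

On an aromatic carbon meta to a large group, methyl(3-(piperidin-1-yl)propyl)amino in place of (3-bromobenzyl)(ethyl)amino gives, in this assay, a number 5.7 percentage points higher from compound 3 to compound 4 (within the scatter), so this exchange cannot be told apart from the scatter. The six-membered aromatic ring and the bromine leave and a piperidine ring enters, and the read-out does not separate the two groups. Nothing available bears on why this is so.

Going by these compounds, whether a morpholine ring or a shorter dimethylamino group at this position would separate from these two remains open. So does the effect of the methyl and propyl parts taken singly.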